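The source may hold more compounds than are shown below. What is called first, only, known or untested is meant among the compounds shown, and "the series" means these compounds.

Measured compounds: compound 1 `CN1CCC[C@H]1COc1cccnc1` with 0.15 nM; compound 2 `CN1CCC[C@H]1COc1cccnc1I` with 606 nM; compound 3 `CCN(CC)C(=O)c1ccncc1OC[C@@H]1CCCN1C` with 2830 nM.

In an assay on membranes from brain for displacement of a labelled ligand from Neuronal acetylcholine receptor; alpha4/beta2 (Rattus norvegicus) (on this read-out higher numbers stand for weaker inhibition and lower numbers for stronger inhibition), compound 1 gives the lowest of the three numbers. Every substitution on its aromatic ring so far has cost much: a 4000-fold higher number from compound 1 to compound 2 (3.61 log units; beyond the scatter) and a 19000-fold higher number from compound 1 to compound 3 (4.28 log units; beyond the scatter) are both large. Compound 4 `CCNc1cncc(OC[C@@H]2CCCN2C)c1` differs from compound 1 by ethylamino in place of hydrogen on an aromatic carbon, a group of 3 heavy atoms placed two atoms from the ring nitrogen and meta to the group of 8 heavy atoms. Among the measured compounds shown here, both measured steps bear on this change, and both point to a higher number, so a step upward in this assay is expected for compound 4, though its size is uncertain with only two precedents of other groups. The estimate for compound 4 is 8 nM, between 0.6 nM and 120 nM, which means a 53-fold higher number from compound 1 to compound 4 (1.73 log units; beyond the scatter).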

Compound 4, inhibition constant: 3.7 nM
Compound 4: middle estimate off by 2.2-fold (0.33 log units), on the high side; the range from low to high includes it.
By their numbers in this assay, from the lowest: compound 1; then compound 4; then compound 2; then compound 3.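

In this assay, ethylamino on this aromatic carbon, two atoms from the ring nitrogen, also raises the number, a 25-fold higher number from compound 1 to compound 4 (1.39 log units; beyond the scatter), so all three substituted compounds lie above compound 1. Even so, this is the smallest of the three steps from compound 1, which shows that the aromatic ring of the core can carry a substituent at a much smaller cost than the earlier steps suggested. No measurement given here accounts for the size of this step.

On these data alone, it remains open whether a plain amine or a longer chain such as propylamino on this carbon would give a smaller or larger step. As far as these compounds go, it also remains open how much of the difference among the three steps belongs to the place and how much to the group.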